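Swapping Trifluoromethyl for Methyl on the Ether Oxygen

A few compounds are considered here, and "the series" means these few. Any claim that something is new, unique, unknown or untested is made for them only; others in the source may bear on it.

In a functional assay on CHO cells for antagonist activity at sphingosine 1-phosphate receptor 2 (Homo sapiens), read by GTPgammaS binding (a higher number here means a weaker inhibitor, a lower number a stronger inhibitor), three compounds have been measured. Compound 1 `COc1ccc(Cl)cc1NC(=O)Cc1nn(CC(=O)O)c(=O)c2ccccc12` gives 1190 nM, compound 2 `O=C(O)Cn1nc(Cc2nc3cc(Cl)c(OC(F)(F)F)cc3[nH]2)c2ccccc2c1=O` gives 342 nM, and compound 3 `CC(C(=O)O)c1nn(Cc2cn3cc(OCC4CC4)c(Cl)cc3n2)c2ccccc2c1=O` gives 31 nM. Compound 2 thus stands second highest of the three: compound 1 sits higher and compound 3 lower, both beyond the scatter. Compound 4 `COc1cc2[nH]c(Cc3nn(CC(=O)O)c(=O)c4ccccc34)nc2cc1Cl` is not yet measured. It differs from compound 2 in one place: methyl in place of trifluoromethyl on an oxygen on an aromatic ring. Among the compounds with values here, no measured pair shows this particular change, so nothing in these data fixes its size. A small step in this assay, toward a weaker inhibitor, is expected, a 1.8-fold higher number from compound 2 to compound 4 (0.24 log units; within the scatter), and one within the scatter would not surprise. Compound 4 is accordingly estimated at 600 nM, with a range from 200 nM to 2000 nM.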

Compound 4, half-maximal inhibitory concentration: 241 nM
Compound 4: middle estimate off by 2.5-fold (0.40 log units), on the high side, and the stated range covers the measured number.
By their numbers in this assay, from the lowest: compound 3; then compounds 4 and 2 (each within the scatter of the next); then compound 1.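

In this assay, this first measured pair for the change gives a 1.4-fold lower number from compound 2 to compound 4 (0.15 log units; within the scatter), so at this position on the aromatic ring the data do not tell methyl and trifluoromethyl apart. That holds even though 4 heavy atoms leave and 1 enters. No measurement shown here accounts for this result. The compounds shown leave open whether other groups on this oxygen, such as ethyl or difluoromethyl, would give a step beyond the scatter. On these data alone, a free hydroxyl in place of the whole ether is equally open.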